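Swapping a Nitrile for a Methyl in Compound 4

A few compounds are considered here, and "the series" means these few. Any claim that something is new, unique, unknown or untested is made for them only; others in the source may bear on it.

Compound 1, `O=C(Oc1ccccc1)N1CCC(CCn2ccc3cc(F)ccc32)CC1`, gives 130 nM in an assay on microsomes from brain for inhibition of Fatty-acid amide hydrolase 1 (Rattus norvegicus), read by HPLC, with a stated time of 60 min; a higher number here means a weaker inhibitor, a lower number a stronger inhibitor.
Compound 2, `O=C(Oc1ccccc1)N1CCC(CCn2ccc3cc(Cl)ccc32)CC1`, gives 410 nM in this assay.
Compound 3, `N#Cc1ccc2c(ccn2CCC2CCN(C(=O)Oc3ccccc3)CC2)c1`, gives 970 nM in this assay.

Among these three, compound 3 stands with the highest number, and so as the weakest inhibitor of the set. Its nearest neighbour is compound 2, and the gap is a 2.4-fold higher number from compound 2 to compound 3 (0.37 log units; beyond the scatter), which lies beyond the scatter. The furthest is compound 1, with a 7.5-fold higher number from compound 1 to compound 3 (0.87 log units; beyond the scatter), also beyond the scatter. The other step within the set, a 3.2-fold higher number from compound 1 to compound 2 (0.50 log units; beyond the scatter), is likewise beyond the scatter. All three compounds share one core and differ only in the group on the same aromatic carbon.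

Compound 4, `Cc1ccc2c(ccn2CCC2CCN(C(=O)Oc3ccccc3)CC2)c1`, carries a further variation at that position: methyl in place of cyano on an aromatic carbon. Within the data shown here, no measured pair exchanges a methyl, so the step rests only on the observation that, of the three groups tried, the nitrile gave the weakest inhibition and the halogens the stronger. A methyl in place of the nitrile is therefore expected to move the number downward, though the size is uncertain.

Compound 4 is estimated at 400 nM in this assay, within a range from 130 nM to 1200 nM, which means an expected step of a 2.4-fold lower number from compound 3 to compound 4 (0.38 log units; beyond the scatter).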

Compound 4, half-maximal inhibitory concentration: 700 nM
Compound 4: the middle estimate sits 1.8-fold (0.24 log units) below what was measured, and the stated range covers the measured number.
By their numbers in this assay, from the lowest: compound 1; then compounds 2, 4 and 3 (each within the scatter of the next, the first and the last beyond it).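

In this assay, replacing the nitrile with a methyl gives a 1.4-fold lower number from compound 3 to compound 4 (0.14 log units; within the scatter), so this exchange, the first at this aromatic carbon to involve neither a halogen nor a nitrile on the incoming side, does not separate the two groups. The methyl also cannot be told apart from chloro, with a 1.7-fold higher number from compound 2 to compound 4 (0.23 log units; within the scatter), yet fluoro remains clearly apart from it, with a 5.4-fold higher number from compound 1 to compound 4 (0.73 log units; beyond the scatter), which leaves compound 1 the strongest inhibitor of the four, while compound 4 sits within the scatter of both compound 2 and compound 3, even though those two are separated from each other beyond the scatter. Nothing available on these compounds explains why fluoro stands apart from the other three groups at this carbon.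

The compounds shown leave open how a methoxy group, an amine or a plain hydrogen at this aromatic carbon would compare with fluoro, and so whether any group here could give a lower number than compound 1. They also leave open whether the same gaps between these groups would persist with a longer chain joining the two halves of the shared core.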